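Trading the Methoxy Arm for a Methyl

A few compounds are considered here, and "the series" means these few. Any claim that something is new, unique, unknown or untested is made for them only; others in the source may bear on it.

Two measured compounds anchor this account. Compound 1 `C[C@@H](c1nnc(-c2ccc(Cl)cc2)o1)[C@H]1CC[C@@H](c2ccnc3ccc(F)cc32)CC1` gives 239 nM in an assay on tissue (HeLa cells) for inhibition of Indoleamine 2,3-dioxygenase 1 (Homo sapiens), read by fluorescence, with a stated time of 18 h; on this read-out higher numbers stand for weaker inhibition and lower numbers for stronger inhibition. Compound 2 `COCC(Nc1nnc(-c2ccc(OC)cc2)o1)[C@H]1CC[C@@H](c2ccnc3ccc(F)cc32)CC1` gives 3 nM in this assay and stands at the lowest of the two numbers; its nearest neighbour is compound 1, which sits at a higher number, and that gap lies well beyond the scatter of the method. The two differ from each other in more than one place, so their values are simply reported side by side.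

Compound 3 `CCC(Nc1nnc(-c2ccc(OC)cc2)o1)[C@H]1CC[C@@H](c2ccnc3ccc(F)cc32)CC1` has not yet been measured in this assay. It differs from compound 2 in one place: methyl in place of methoxy on a saturated chain carbon, two bonds along the chain from a nitrogen on an aromatic ring and a saturated ring carbon. For the measured compounds named here, no measured pair shows this same change, so its size cannot be read from the data. Since compound 2 already gives 3 nM, a low number, the step of a 2.0-fold higher number from compound 2 to compound 3 (0.30 log units; within the scatter) is expected to be small, toward a somewhat higher number, or none beyond the scatter. On that basis compound 3 is estimated at 6 nM, with a range from 1.5 nM to 25 nM.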

Compound 3, half-maximal inhibitory concentration: 6 nM
The estimate for compound 3 equals the measured number at the digits printed, and the stated range covers the measured number.
By their numbers in this assay, from the lowest: compounds 2 and 3 (each within the scatter of the next); then compound 1.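

For the compounds shown here, the change from methoxy to methyl on this saturated chain carbon gives a 2.0-fold higher number from compound 2 to compound 3 (0.30 log units; within the scatter) in this assay, the first direct reading at this place, and compound 2 and compound 3 cannot be told apart on this read-out. In this single pair, a low number therefore does not depend on the oxygen that leaves with the methoxy or on its hydrogen-bond acceptor, and the same difference can equally be read as methoxymethyl to ethyl. Compound 1 differs from both in more than one place, so it could not show this, and no supporting measurement is available to explain why the two compounds read alike.

The compounds shown leave open how an amine, a hydroxyl or a longer chain such as propyl would read on this same carbon. Going by these compounds alone, they also leave open whether methyl in place of methoxy would read the same way if the shared core carried a different group elsewhere, since this one pair is the only reading of the change.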